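The source may hold more compounds than are shown below. What is called first, only, known or untested is meant among the compounds shown, and "the series" means these compounds.

Measured so far:
- compound 1, `CCCCCCNC(=O)n1cc(N(C)Cc2ccccc2)c(=O)[nH]c1=O`, 5500 nM
- compound 2, `CCCCCCNC(=O)n1cc(N2CCN(C)CC2)c(=O)[nH]c1=O`, 1400 nM

Both numbers come from an assay on HEK293 cells for inhibition of acid ceramidase (Rattus norvegicus), read by LC-MS, with a stated time of 30 min; a lower number here means a stronger inhibitor, a higher number a weaker inhibitor. Compound 2 stands lowest of the two; compound 1 sits higher by a gap that exceeds the usual scatter of this assay, so compound 2 is the stronger inhibitor here. The next compound, compound 3, `CCCCCCNC(=O)n1cc(NC)c(=O)[nH]c1=O`, is not yet measured. It differs from compound 2 in one place: methylamino in place of 4-methylpiperazin-1-yl on an aromatic carbon. For the measured compounds named here, with no measured step of this kind to lean on, the expected change from compound 2 to compound 3 is a moderate rise, a 2.1-fold higher number from compound 2 to compound 3 (0.33 log units; beyond the scatter), that is, a somewhat weaker inhibitor. Compound 3 is therefore estimated at 3000 nM, within a range of 1000 nM to 10000 nM.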

Compound 3, half-maximal inhibitory concentration: 3400 nM
Estimate against measurement, compound 3: 1.1-fold (0.05 log units) below, and the stated range covers the measured number.
By their numbers in this assay, from the lowest: compound 2; then compounds 3 and 1 (each within the scatter of the next).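

Replacing 4-methylpiperazin-1-yl with the smaller methylamino on this aromatic carbon gives a 2.4-fold higher number from compound 2 to compound 3 (0.39 log units; beyond the scatter) in this assay, so the group held here does matter, though only modestly. Hydrogen in place of benzyl on the nitrogen gives a 1.6-fold lower number from compound 1 to compound 3 (0.21 log units; within the scatter) and this step cannot be told apart from repeat-measurement variation. No available measurement explains why these numbers differ. Going by these compounds, whether a carboxylic acid or a plain amine on this aromatic carbon would bring the number lower remains open. So does whether a piperidine ring would hold the level of compound 2.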